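Pyrazole demethylation in compound 3: expected outcome for compound 4

The source may report more compounds than this note shows. Statements on the series, on what has been measured and on what is new or still open speak of the compounds shown alone.

Measured compounds:
- compound 1 `Cc1cnn(C(=O)N(C)CCN(C)Cc2ccc(OCc3ccccc3)cc2)c1`: > 100000 nM in an assay on membranes from brain for binding affinity to neutral cholesterol ester hydrolase 1 (Mus musculus), read by fluorescence, with stated times of 1 h and 30 min; a lower number here means a stronger inhibitor, a higher number a weaker inhibitor
- compound 2 `O=C(NCc1ccc(OC(c2ccccc2)c2ccccc2)cc1)n1cccn1`: > 100000 nM in this assay
- compound 3 `Cc1cnn(C(=O)N2CCN(C(c3ccc4ccccc4c3)c3ccc4ccccc4c3)CC2)c1`: > 100000 nM in this assay

For compound 3 the value is a limit of the assay, not a number. The same holds for compound 1, and the same holds for compound 2. All three results therefore sit at one place, (the limit of > 100000 nM in this assay, at which 3 of the 3 values shown sit), and no comparison between them can be drawn: none is stronger or weaker than another on these data. Compound 3 stands where the rest of the series stands, at the limit.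

Compound 4 `O=C(N1CCN(C(c2ccc3ccccc3c2)c2ccc3ccccc3c2)CC1)n1cccn1` is the next analog and differs from compound 3 in one place: hydrogen in place of methyl on an aromatic carbon. Among the measured compounds shown here, no step between measured compounds is available, so the size of this change cannot be read from a measured pair. Given that compound 3 gives > 100000 nM, the expectation is that the change produces no step beyond the scatter, a number no higher from compound 3 to compound 4 (the limit leaves the size open), and that compound 4 most likely also returns a limit. The estimate for compound 4 is 100000 nM, with a range from 30000 nM to 300000 nM.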

Compound 4, half-maximal inhibitory concentration: > 100000 nM
Compound 4: no number, only a limit (the forecaster's own chance of this, stated with the estimate: 85%); the middle value lies on the limit itself.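

Compound 3 and compound 4 both sit at a limit of the assay, not at a number, so no step can be read for the change from 4-methyl-1H-pyrazol-1-yl to 1H-pyrazol-1-yl: the limit of > 100000 nM in this assay, at which 4 of the 4 values shown sit.

The compounds shown leave open whether removing the methyl changes inhibition at all in this assay, and what value any of these compounds would give as a number.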